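Swapping the Phenyl for Bromo on the Shared Core

The source may report more compounds than this note shows. Statements on the series, on what has been measured and on what is new or still open speak of the compounds shown alone.

Of the compounds shown here, three built on one shared core have been tested in a functional assay on the whole organism (strain Wistar) for inhibition, with Rattus norvegicus as the target, read by paw edema, with stated times of 30 min and 3 h, at a dose of 0.05 mmol/kg by the oral route; a higher number here means more inhibition at the dose given (going by the name of the read-out), a lower number less inhibition. Compound 1 `Cc1cc(C2=NN(c3ccc(S(C)(=O)=O)cc3)C(=O)CC2)ccc1O` gives 26.6% and compound 2 `CS(=O)(=O)c1ccc(N2N=C(c3ccccc3)CCC2=O)cc1` gives 26.6%, with the step of no change at the digits printed from compound 1 to compound 2 (within the scatter). Compound 3 `CS(=O)(=O)c1ccc(N2N=C(c3ccc(-c4ccccc4)cc3)CCC2=O)cc1` gives 6.6%, the lowest of the three numbers, reached through the step of a number 20 percentage points lower from compound 2 to compound 3 (beyond the scatter).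

Compound 4 `CS(=O)(=O)c1ccc(N2N=C(c3ccc(Br)cc3)CCC2=O)cc1` differs from compound 3 by bromo in place of phenyl on an aromatic carbon. Among the measured compounds shown here, no measured step shows bromo entering or phenyl leaving directly; the step that bears on it is the one where a phenyl entered, a number 20 percentage points lower from compound 2 to compound 3 (beyond the scatter). Compound 4 gives that phenyl up for a single bromine, so part of that loss is expected to be undone in this assay, with the expected step of a number 13.4 percentage points higher from compound 3 to compound 4 (beyond the scatter). Compound 4 is therefore estimated at 20%, within a range from 5% to 35%.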

Compound 4, a percentage reported as inhibition, in the whole organism at one dose (the size of the read-out at that dose, not a potency): 10%
Estimate against measurement, compound 4: 10 percentage points above; measured number inside the range.
By their numbers in this assay, from the lowest: compounds 3 and 4 (each within the scatter of the next); then compounds 1 and 2 (each within the scatter of the next).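

In this assay, bromo and phenyl at this aromatic carbon cannot be told apart, with a number 3.4 percentage points higher from compound 3 to compound 4 (within the scatter). Bromo still costs inhibition against the hydrogen it replaces, with a number 16.6 percentage points lower from compound 2 to compound 4 (beyond the scatter), and the 4-bromophenyl group does the same in place of 4-hydroxy-3-methylphenyl, with a number 16.6 percentage points lower from compound 1 to compound 4 (beyond the scatter), so the loss at this carbon comes with a single bromine as well as with a whole phenyl. Nothing available here explains this loss. Still open, from the compounds shown here alone, is whether a fluoro or an amino group on this carbon would stay near compound 2 at 26.6% or would match bromo and phenyl.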